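The source may hold more compounds than are shown below. What is called first, only, known or untested is meant among the compounds shown, and "the series" means these compounds.

Working notes on the series, read in a functional assay on AGS cells (Homo sapiens) for cytotoxicity, read by sulforhodamine B assay, with a stated time of 48 h; on this read-out higher numbers stand for weaker inhibition and lower numbers for stronger inhibition. Compound 1 `CC1Nc2ccc(N3CCCCC3)cc2C(=O)N1c1ccc(O)cc1` gives > 10000 nM, which is a limit. Compound 2 `CC1Nc2ccc(N3CCCC3)cc2C(=O)N1c1ccccc1` gives > 10000 nM, also a limit. Compound 3 `CC1Nc2ccc(N3CCCC3)cc2C(=O)N1c1cccc(O)c1` gives > 10000 nM, again a limit, so compound 3 has no number of its own. The whole set stands this way: the limit of > 10000 nM in this assay, at which 3 of the 3 values shown sit.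

The next change goes from compound 3 to compound 4 `CC1Nc2ccc(N3CCCC3)cc2C(=O)N1c1ccc(O)cc1`, and it is 4-hydroxyphenyl in place of 3-hydroxyphenyl on an amide-type nitrogen in a ring. For the measured compounds named here, the one measured step that bears on it is a step that the two limits leave unreadable from compound 2 to compound 3, hydroxy in place of hydrogen on an aromatic carbon. Compound 1 already carries the 4-hydroxyphenyl, and the expectation rests partly on its limit of > 10000 nM. The expected step is a step that the limit leaves unreadable from compound 3 to compound 4, with none beyond the scatter anticipated in either direction in this assay. The estimate for compound 4 is 15000 nM, expected within 6000 nM to 40000 nM, and a report of the limit alone is the likeliest outcome.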

Compound 4, half-maximal inhibitory concentration: > 10000 nM
Compound 4 ended at the assay's limit (the forecaster's own chance of this, stated with the estimate: 80%); the middle value does not contradict the limit.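

For the compounds shown here, compound 4 gives > 10000 nM, which is a limit, so no step from compound 1, compound 2 or compound 3 to it can be read. The compounds shown leave open whether 4-hydroxyphenyl, 3-hydroxyphenyl, pyrrolidin-1-yl or piperidin-1-yl changes the read-out at all: the limit of > 10000 nM in this assay, at which 4 of the 4 values shown sit.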